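Changing the acid-bearing chain in a receptor agonist series

The source may report more compounds than this note shows. Statements on the series, on what has been measured and on what is new or still open speak of the compounds shown alone.

Measured compounds:
Compound 1, `Cc1nc(-c2ccc(C(F)(F)F)cc2)sc1CNc1ccc(CCC(=O)O)cc1`, in a functional assay on CHO cells for agonist activity at Free fatty acid receptor 1 (Homo sapiens), read by a luciferase reporter (on this read-out higher numbers stand for larger maximal responses and lower numbers for smaller maximal responses), gives 108%.
Compound 2, `Cc1nc(-c2ccc(C(F)(F)F)cc2)sc1CNc1ccc(OCC(=O)O)cc1`, in this assay gives 100%.

Compound 2 stands at the lower of these two numbers, but only by the step of a number 8 percentage points lower from compound 1 to compound 2 (within the scatter), which is within the scatter. Compound 3, `Cc1nc(-c2ccc(C(F)(F)F)cc2)sc1CNc1ccc(CC(C)C(=O)O)cc1`, differs from compound 2 by 2-carboxypropyl in place of carboxymethoxy on an aromatic carbon. Within the data shown here, the one measured step that bears on this change, a number 8 percentage points lower from compound 1 to compound 2 (within the scatter), also altered the acid-bearing chain and stayed within the scatter, so no step beyond the scatter is expected in this assay. The expected step of no change at the digits printed from compound 2 to compound 3 (within the scatter) is accordingly small. Compound 3 is therefore estimated to give 100%, in a range from 80% to 115%.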

Compound 3, largest response reached (reported as percent of maximum), in percent of the reference or control that the assay uses: 100%
The estimate for compound 3 equals the measured number at the digits printed, within the range that was stated.
By their numbers in this assay, from the lowest: compounds 2, 3 and 1 (each within the scatter of the next).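

In this assay, the change to 2-carboxypropyl gives no change at the digits printed from compound 2 to compound 3 (within the scatter), so this position tolerates this chain as well as carboxymethoxy on this read-out. Methyl on the saturated chain carbon bound to the carbonyl carbon gives a number 8 percentage points lower from compound 1 to compound 3 (within the scatter), so this branch also leaves the maximal response within the scatter. Nothing available here explains why these chains read alike. The compounds shown leave open whether a tetrazole in place of the carboxylic acid, or a longer chain bearing it, would keep this maximal response.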